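A few compounds are considered here, and "the series" means these few. Any claim that something is new, unique, unknown or untested is made for them only; others in the source may bear on it.

Measured compounds:
Compound 1 `COC(=O)c1sc2cc(OC)ccc2c1Nc1cc(OC)c(OC)c(OC)c1` gives 8.5 nM in a functional assay on A549 cells (Homo sapiens) for cytotoxicity, read by MTT assay, with a stated time of 72 h; a higher number here means a weaker inhibitor, a lower number a stronger inhibitor.
Compound 2 `COC(=O)c1sc2ccccc2c1Nc1cc(OC)c(OC)c(OC)c1` gives 2850 nM in this assay.
Compound 3 `CCOC(=O)c1sc2cc(OC)ccc2c1Nc1cc(OC)c(OC)c(OC)c1` gives 8.9 nM in this assay.

Compound 3 stands second highest of the three numbers. Its nearest neighbour is compound 1, and the step of a 1.0-fold higher number from compound 1 to compound 3 (0.02 log units; within the scatter) shows the two sit within the scatter of each other. Compound 2 stands far higher than compound 3.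

Compound 4 `CCOC(=O)c1sc2ccccc2c1Nc1cc(OC)c(OC)c(OC)c1` is compound 3 with one change: hydrogen in place of methoxy on an aromatic carbon. The same change has been measured once before, in the step of a 340-fold higher number from compound 1 to compound 2 (2.53 log units; beyond the scatter), which was large. Since compound 3 and compound 1 differ only by a methyl on the ester chain, a step of similar size and direction is expected here, a 340-fold higher number from compound 3 to compound 4 (2.53 log units; beyond the scatter).

Compound 4 is therefore expected to give about 3000 nM, within a range from 900 nM to 10000 nM.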

Compound 4, half-maximal inhibitory concentration: 8530 nM
For compound 4 the middle estimate is 2.8-fold (0.45 log units) below the measured one; the range from low to high includes it.
By their numbers in this assay, from the lowest: compounds 1 and 3 (each within the scatter of the next); then compound 2; then compound 4.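

Replacing the methoxy with hydrogen again carries a large cost in this assay, with a 960-fold higher number from compound 3 to compound 4 (2.98 log units; beyond the scatter), so the loss holds on both ester chains. Its size still depends on the chain: the same change on two cores in this assay, a 340-fold higher number (2.53 log units; beyond the scatter) from compound 1 to compound 2 and a 960-fold higher number (2.98 log units; beyond the scatter) from compound 3 to compound 4, 2.9-fold (0.46 log units) apart, beyond the scatter of two such steps The added methyl on the ester chain, which changes nothing measurable when the methoxy is present, now gives a 3.0-fold higher number from compound 2 to compound 4 (0.48 log units; beyond the scatter), a dependence seen from the other side: the same change on two cores in this assay, a 1.0-fold higher number (0.02 log units; within the scatter) from compound 1 to compound 3 and a 3.0-fold higher number (0.48 log units; beyond the scatter) from compound 2 to compound 4, 2.9-fold (0.46 log units) apart, beyond the scatter of two such steps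

From the compounds shown here alone, whether a hydroxyl, a fluorine or an ethoxy at this ring position would keep the number low remains open. So does the outcome for a propyl ester or an amide in place of the ester.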